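The source may report more compounds than this note shows. Statements on the series, on what has been measured and on what is new or still open speak of the compounds shown alone.

Of the compounds shown here, three sharing one core have been tested in an assay on isolated protein for inhibition of DNA topoisomerase 1 (Homo sapiens), with a stated time of 15 min; a lower number here means a stronger inhibitor, a higher number a weaker inhibitor. Compound 1, `CN[C@@H]1CCN(c2c(F)cc3c(=O)c(C(=O)O)cn(Cc4ccc(-c5ccccc5)cc4)c3c2OC)C1`, gives 57700 nM. Compound 2, `COc1c(N2CC[C@@H](N)C2)c(F)cc2c(=O)c(C(=O)O)cn(Cc3ccc(-c4ccccc4)cc3)c12`, gives 92200 nM. Compound 3, `NC[C@@H]1CCN(c2cc3c(cc2F)c(=O)c(C(=O)O)cn3Cc2ccc(-c3ccccc3)cc2)C1`, gives 15600 nM, the lowest of the three numbers. Compounds 2 and 1 differ in one place, (methyl in place of hydrogen on an amine nitrogen), and this change gave a 1.6-fold lower number from compound 2 to compound 1 (0.20 log units; within the scatter). Compound 3 differs from compound 2 in more than one place, and that difference between the two cores is not broken down here.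

Compound 4, `CNC[C@@H]1CCN(c2cc3c(cc2F)c(=O)c(C(=O)O)cn3Cc2ccc(-c3ccccc3)cc2)C1`, has not yet been measured. It differs from compound 3 by methyl in place of hydrogen on an amine nitrogen. This is the same kind of change as from compound 2 to compound 1, but around the place something differs: in compound 2 the amine nitrogen sits on a saturated ring carbon, in compound 3 on a saturated chain carbon.

For compound 4 the expected step is a 1.3-fold lower number from compound 3 to compound 4 (0.11 log units; within the scatter), a small step beside the earlier one, because a 1.6-fold lower number from compound 2 to compound 1 (0.20 log units; within the scatter) stayed within the scatter. In this assay compound 4 is therefore estimated at 12000 nM, between 5000 nM and 30000 nM.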

Compound 4, half-maximal inhibitory concentration: 168000 nM
For compound 4 the middle estimate is 14-fold (1.15 log units) below the measured one; measured number above the stated range.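

Placing a methyl on the amine nitrogen gave an 11-fold higher number from compound 3 to compound 4 (1.03 log units; beyond the scatter) in this assay, which shows that this change did not keep its size or direction when carried from one core to the other: the same change on two cores in this assay, a 1.6-fold lower number (0.20 log units; within the scatter) from compound 2 to compound 1 and an 11-fold higher number (1.03 log units; beyond the scatter) from compound 3 to compound 4, 17-fold (1.24 log units) apart, beyond the scatter of two such steps In compound 4 the nitrogen sits on a saturated chain carbon, within a (methylamino)methyl group, whereas in compound 1 it sits on a saturated ring carbon, and the two cores also differ in other places. These two pairs do not show which of those differences matters or why the step changed; they show only that, here, the step on one core was a poor guide to the step on the other.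

Pairing the aminomethyl and (methylamino)methyl groups on the core of compound 1 would test whether the place of the amine or the rest of the core goes with the larger step. Also open, from the compounds shown here alone, is whether an ethyl group on the same nitrogen would follow the methyl.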